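The source may report more compounds than this note shows. Statements on the series, on what has been measured and on what is new or still open speak of the compounds shown alone.

Compound 1, `COc1ccc(Cn2c(-c3ccccc3)c(-c3ccccc3)c3c(=N)n([C@H]4CC[C@H](O)CC4)cnc32)cc1`, gives in an ADME assay for permeability, using PAMPA, with a stated time of 30 min, at pH 7.4; a lower number here means that the compound crosses the layer more slowly, a higher number that the compound crosses the layer faster > 1000 10^-6 cm/s, which is a limit of the assay.
Compound 2, `COc1ccc(Cn2c(-c3ccccc3)c(-c3ccccc3)c3c(=N)n(CCCO)cnc32)cc1`, gives in this assay > 1000 10^-6 cm/s, again a limit.
Compound 3, `COc1ccc(Cn2c(-c3ccccc3)c(-c3ccccc3)c3c(=N)n(CC4CCCO4)cnc32)cc1`, gives in this assay > 1000 10^-6 cm/s, also a limit.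

Compound 3 therefore stands at the upper edge of what the assay can report, together with the other two compounds: the limit of > 1000 10^-6 cm/s in this assay, at which 3 of the 3 values shown sit. Compound 4, `COc1ccc(Cn2c(-c3ccccc3)c(-c3ccccc3)c3c(=N)n(CCO)cnc32)cc1`, differs from compound 3 in one place: hydroxymethyl in place of oxolan-2-yl on a saturated chain carbon bound to an aromatic nitrogen. The measured steps that touch this side chain are a step that the two limits leave unreadable from compound 1 to compound 2, a step that the two limits leave unreadable from compound 1 to compound 3 and a step that the two limits leave unreadable from compound 2 to compound 3. None of them can be sized. No readable step is expected in this assay from compound 3 to compound 4, so the estimated step is a step that the limit leaves unreadable from compound 3 to compound 4. Compound 4 is expected to give 1200 10^-6 cm/s, estimated between 600 10^-6 cm/s and 2500 10^-6 cm/s.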

Compound 4, apparent permeability: > 1000 10^-6 cm/s
Compound 4 was reported as a limit; the forecaster's own chance of this, stated with the estimate: 85%; the middle value does not contradict the limit.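

No step from compound 1, compound 2 or compound 3 to compound 4 can be read, because all of these values are limits: the limit of > 1000 10^-6 cm/s in this assay, at which 4 of the 4 values shown sit.

The compounds shown leave open whether these side chains on the aromatic nitrogen differ at all in this assay.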